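The source may hold more compounds than are shown below. What is called first, only, known or untested is meant among the compounds shown, and "the series" means these compounds.

Measured in a functional assay on T47D cells (Homo sapiens) for cytotoxicity, read by MTT assay, with a stated time of 2 days; a higher number here means a weaker inhibitor, a lower number a stronger inhibitor:
- compound 1 `CN(C)c1ccc2nc(-c3cccc4ccccc34)[nH]c(=O)c2c1`: > 50000 nM
- compound 2 `CCN(CC)c1ccc2nc(-c3ccccc3OC(F)(F)F)[nH]c(=O)c2c1`: 1670 nM

Compound 1 gives > 50000 nM, which is a limit, not a number. Compound 3 `CCN(CC)c1ccc2nc(-c3cccc4ccccc34)[nH]c(=O)c2c1` has diethylamino in place of dimethylamino on an aromatic carbon of the core of compound 1 (diethylamino in place of dimethylamino on an aromatic carbon). Compound 2 also carries diethylamino and gives 1670 nM, but it differs from compound 3 elsewhere, so it is only a loose guide. A moderate step towards stronger inhibition in this assay is expected, with the estimated change being an at least 4.1-fold lower number from compound 1 to compound 3 (0.61 log units; beyond the scatter). A reading that again reports only a limit remains quite possible. For compound 3 the expected value is 12000 nM, with an estimated range of 2500 nM to 50000 nM.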

Compound 3, half-maximal inhibitory concentration: 2690 nM
The estimate for compound 3 lay 4.5-fold (0.65 log units) above the measured number, within the range that was stated.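

With the rest of the structure unchanged, diethylamino in place of dimethylamino on this aromatic carbon gives an at least 18-fold lower number from compound 1 to compound 3 (1.26 log units; beyond the scatter) in this assay. This one-place change alone takes the series from a limit to a measured value. Compound 1 gives > 50000 nM, which is a limit and not a number, so the step is a bound and its true size stays unknown: the limit of > 50000 nM in this assay, at which 1 of the 3 values shown sits.

From the compounds shown here alone, whether the trend continues to a longer chain such as dipropylamino remains open. So does the outcome with a cyclic amine such as pyrrolidine or morpholine at this position.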